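Ester change on two cores: benzyl for tert-butyl

The compounds below may be only part of what the source reports. "The series", "measured", "known", "first", "only" and "open" are said of these compounds alone.

Working notes on a small set of ureas and a thiourea sharing an ester on the core. Compound 1 `CC1=C(C(=O)OC(C)(C)C)C(c2ccsc2)NC(=O)N1` gives 1% in an assay on membranes from HeLa cells for displacement of a labelled ligand from adenosine receptor A3 (Homo sapiens), read by scintillation counting, with a stated time of 180 min, tested at 1 uM; on this read-out higher numbers stand for more inhibition at the one concentration tested (going by the name of the read-out) and lower numbers for less inhibition. Compound 2 `CC1=C(C(=O)OCc2ccccc2)C(c2ccsc2)NC(=O)N1` gives 25% in this assay; the change here is benzyl in place of tert-butyl on an oxygen next to a carbonyl group, and the step is a number 24 percentage points higher from compound 1 to compound 2 (beyond the scatter). Compound 3 `CC1=C(C(=O)OC(C)(C)C)C(c2ccco2)NC(=S)N1` gives 9% in this assay; the difference between its core and the core of compound 1 is not broken down here. Compound 4 `CC1=C(C(=O)OCc2ccccc2)C(c2ccco2)NC(=S)N1` is not yet measured. It carries the same change as compound 2 against compound 1, namely (benzyl in place of tert-butyl on an oxygen next to a carbonyl group), at the same place. For compound 4 a step of a number 24 percentage points higher from compound 3 to compound 4 (beyond the scatter) in this assay is expected because the same change gave a number 24 percentage points higher from compound 1 to compound 2 (beyond the scatter). Compound 4 is accordingly estimated at 33%, with a range from 12% to 55%.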

Compound 4, a percentage reported as inhibition, at one concentration (the size of the read-out at that concentration, not a potency): 4%
Estimate against measurement, compound 4: 29 percentage points above; measured number below the stated range.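

In this assay, benzyl in place of tert-butyl does not carry over from the core of compound 1 to the core of compound 3, where the new step is a number 5 percentage points lower from compound 3 to compound 4 (within the scatter). The two steps differ: the same change on two cores in this assay, a number 24 percentage points higher (beyond the scatter) from compound 1 to compound 2 and a number 5 percentage points lower (within the scatter) from compound 3 to compound 4, 29 percentage points apart, beyond the scatter of two such steps. This shows that the step seen on one core cannot be assumed on the other, but it does not show which difference between the two cores sets the steps apart, and two pairs give no rule for any further core.

Still open, as far as these compounds go, is how a longer chain on the oxygen next to a carbonyl group would read on either core. Also open, from the compounds shown here alone, is how a carboxylic acid or an amine-derived amide in place of the ester would read in this assay.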